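Furan for Thiophene on a Methylamino Nucleoside Core

This account rests on a few compounds, and the source may have more. Where it says the series, first, only, none or still open, it means among the compounds named here.

Compound 1 `CNc1ncnc2c1c(-c1ccsc1)cn2[C@@H]1O[C@H](CO)[C@@H](O)[C@H]1O` is one of three close relatives that share a core and differ in a single group. In a functional assay on HL-60 cells (Homo sapiens) for antiproliferative activity, read by XTT assay, with a stated time of 72 h (on this read-out lower numbers stand for stronger inhibition and higher numbers for weaker inhibition), compound 1 gives > 20000 nM, which is a limit of the assay rather than a number; it sits at the limit of > 20000 nM in this assay, at which 1 of the 3 values shown sits. Compound 2 `Cc1ncnc2c1c(-c1ccsc1)cn2[C@@H]1O[C@H](CO)[C@@H](O)[C@H]1O` carries methyl in that place and gives 350 nM, while compound 3 `CSc1ncnc2c1c(-c1ccsc1)cn2[C@@H]1O[C@H](CO)[C@@H](O)[C@H]1O` carries methylsulfanyl and gives 4590 nM; the steps of an at least 57-fold lower number from compound 1 to compound 2 (1.75 log units; beyond the scatter), an at least 4.3-fold lower number from compound 1 to compound 3 (0.63 log units; beyond the scatter) and a 13-fold higher number from compound 2 to compound 3 (1.12 log units; beyond the scatter) all concern that one group. Compound 4 `CNc1ncnc2c1c(-c1ccco1)cn2[C@@H]1O[C@H](CO)[C@@H](O)[C@H]1O` keeps methylamino and instead alters the other substituent: furan-2-yl in place of thiophen-3-yl on an aromatic carbon. Among the measured compounds shown here, no measured step touches this position, so the size of its effect is unknown. Compound 4 is therefore expected to remain near the limit, with a step that the limit leaves unreadable from compound 1 to compound 4, estimated at 25000 nM within 8000 nM to 80000 nM.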

Compound 4, half-maximal inhibitory concentration: 620 nM
Beside the measured number, compound 4's estimate is 40-fold (1.61 log units) above it; the measured number lies below the stated range.
By their numbers in this assay, from the lowest: compounds 2 and 4 (each within the scatter of the next); then compound 3. At a limit, above all of these: compound 1.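

In this assay, furan-2-yl in place of thiophen-3-yl gives an at least 32-fold lower number from compound 1 to compound 4 (1.50 log units; beyond the scatter), with methylamino kept, so this position matters as much as the group changed in compounds 1 to 3. It also shows that the methylamino series can be active once this ring changes. Compound 1 gives only a limit, so this step is a bound and not an exact size: the limit of > 20000 nM in this assay, at which 1 of the 4 values shown sits.

On these data alone, whether the same ring change would help with methyl or methylsulfanyl in place of methylamino remains open. So does the effect of a phenyl ring or an amine at this position.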